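The source may hold more compounds than are shown below. What is called first, only, known or untested is meant among the compounds shown, and "the series" means these compounds.

Measured so far in the series:
Compound 1, `Cc1ccc(CS/C(=C/c2ccc(N(C)C)cc2)C(=O)c2ccc(Cl)cc2)cc1` — in a functional assay on DU-145 cells (Homo sapiens) for inhibition, read by trypan blue exclusion, with a stated time of 96 h (on this read-out lower numbers stand for stronger inhibition of growth and higher numbers for weaker inhibition of growth), compound 1 sits at the assay limit, > 100000 nM.
Compound 2, `Cc1ccsc1/C=C(/SCc1ccc(F)cc1)C(=O)c1ccc(Cl)cc1` — in this assay compound 2 gives 50000 nM.
Compound 3, `Cc1ccc(CS/C(=C/c2ccccc2F)C(=O)c2ccc(Cl)cc2)cc1` — in this assay compound 3 gives 10000 nM.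

Compound 3 holds the lowest of the two real numbers; compound 2 lies higher, beyond the scatter, and compound 1 is a limit only, (the limit of > 100000 nM in this assay, at which 1 of the 3 values shown sits). For the measured compounds named here, the one single-place step known, an at least 10-fold lower number from compound 1 to compound 3 (1.00 log units; beyond the scatter), shows that the aryl group on the double-bonded chain carbon moves the read-out strongly.

Compound 4, `Cc1ccc(CS/C(=C/c2sccc2C)C(=O)c2ccc(Cl)cc2)cc1`, differs from compound 3 by 3-methylthiophen-2-yl in place of 2-fluorophenyl on a double-bonded chain carbon bound to a double-bonded chain carbon. Compound 2 carries the same 3-methylthiophen-2-yl group and gives the higher number, so compound 4 is expected to move upward by a 3.0-fold higher number from compound 3 to compound 4 (0.48 log units; beyond the scatter). The estimate for compound 4 in this assay is 30000 nM, within 8000 nM to 100000 nM.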

Compound 4, concentration for 50% growth inhibition: 10000 nM
Beside the measured number, compound 4's estimate is 3.0-fold (0.48 log units) above it; low and high end bracket the measured number.
By their numbers in this assay, from the lowest: compounds 3 and 4 (each within the scatter of the next); then compound 2. At a limit, above all of these: compound 1.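

In this assay, 3-methylthiophen-2-yl on a double-bonded chain carbon bound to a double-bonded chain carbon gives no change at the digits printed from compound 3 to compound 4 (within the scatter), so this position accepts the five-membered ring and the 2-fluorophenyl ring alike. Methyl in place of fluoro on an aromatic carbon gives a 5.0-fold lower number from compound 2 to compound 4 (0.70 log units; beyond the scatter), the first single-place reading away from this position. Against 4-(dimethylamino)phenyl, the same group gives an at least 10-fold lower number from compound 1 to compound 4 (1.00 log units; beyond the scatter), and compound 1 is a limit only: the limit of > 100000 nM in this assay, at which 1 of the 4 values shown sits.

Open, as far as these compounds go, is whether an amine or a carboxylic acid on the aryl ring at this position keeps the number. Also open, from the compounds shown here alone, is whether the methyl and fluoro step holds with 2-fluorophenyl on the chain.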